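This account rests on a few compounds, and the source may have more. Where it says the series, first, only, none or still open, it means among the compounds named here.

Measured compounds in a functional assay on the whole organism (blood) with Rattus norvegicus as the target, with stated times of 24 h and 1 h, at a dose of 5 mg/kg by the intraperitoneal route; a higher number here means a stronger effect of the compound at the dose given, a lower number a weaker effect:
compound 1 `Cc1ncsc1C(=O)NCCC1CCN(S(=O)(=O)NC(=O)NC[C@@H]2C[C@@H]3C=C[C@@H]2C3)CC1` gives 11%
compound 2 `COc1ccncc1C(=O)NCCC1CCN(S(=O)(=O)NC(=O)NC[C@@H]2C[C@@H]3C=C[C@@H]2C3)CC1` gives 14%
compound 3 `O=C(NC[C@@H]1C[C@@H]2C=C[C@@H]1C2)NS(=O)(=O)N1CCC(CCNC(=O)c2cc(Cl)ccn2)CC1` gives 32%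

Compound 3 stands highest of the three numbers in this assay; its nearest neighbour is compound 2, its furthest compound 1, and both gaps lie beyond the scatter. The step from compound 1 to compound 2 is a number 3 percentage points higher from compound 1 to compound 2 (within the scatter), while a number 21 percentage points higher from compound 1 to compound 3 (beyond the scatter) and a number 18 percentage points higher from compound 2 to compound 3 (beyond the scatter) are modest rises toward compound 3.

Compound 4 `O=C(NC[C@@H]1C[C@@H]2C=C[C@@H]1C2)NS(=O)(=O)N1CCC(CCNC(=O)c2cccc3cccnc23)CC1` is not yet measured. Its change from compound 3 is quinolin-8-yl in place of 4-chloropyridin-2-yl on a carbonyl carbon. Within the data shown here, no measured step exchanges this aryl group, so the two steps that reach compound 3 bear on it only loosely: each heteroaryl swap on the carbonyl carbon moved the number modestly or not beyond the scatter. A step of similar modest size is expected here, more likely downward, as the group that gave compound 3 its lead is removed. Compound 4 is estimated at 22%, in the range 5% to 40%, which means an expected step of a number 10 percentage points lower from compound 3 to compound 4 (within the scatter).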

Compound 4, a percentage reported as activity, at one dose (the size of the read-out at that dose, not a potency): 34%
Beside the measured number, compound 4's estimate is 12 percentage points below it; low and high end bracket the measured number.
By their numbers in this assay, from the lowest: compounds 1 and 2 (each within the scatter of the next); then compounds 3 and 4 (each within the scatter of the next).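

In this assay, a two-ring group on the carbonyl carbon reads like a one-ring group: a number 2 percentage points higher from compound 3 to compound 4 (within the scatter) shows that quinolin-8-yl, with 10 heavy atoms and no chlorine, holds the level of 4-chloropyridin-2-yl, with 7 heavy atoms including chlorine. The separation from the other two compounds therefore no longer rests on 4-chloropyridin-2-yl alone, as a number 20 percentage points higher from compound 2 to compound 4 (beyond the scatter) and a number 23 percentage points higher from compound 1 to compound 4 (beyond the scatter) both lie beyond the scatter. Nothing available explains why these groups separate in this way.

Open, going by these compounds, is whether a ring of carbon only, such as naphthalen-1-yl, or a saturated group, such as cyclohexyl, would hold the same level on the carbonyl carbon. Each number comes from a single dose, so the potency of compound 3 and compound 4 remains unread.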